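This account rests on a few compounds, and the source may have more. Where it says the series, first, only, none or still open, it means among the compounds named here.

Measured compounds:
compound 1 `CC(C)[C@H]1NC(=O)[C@H](CCCNC(=N)N)NC(=O)CNC(=O)C[C@@H](C(=O)O)NC(=O)[C@@H](c2ccccc2)NC1=O` 7.3 nM
compound 2 `N=C(N)NCCC[C@@H]1NC(=O)CNC(=O)C[C@@H](C(=O)O)NC(=O)[C@@H](c2ccccc2)NC(=O)[C@H](CCCCN)NC1=O` 94 nM

The account concerns two cyclic peptides tested in an assay on a protein complex for binding affinity to integrin alpha-5/beta-1 (Homo sapiens), read by ELISA; on this read-out lower numbers stand for stronger inhibition and higher numbers for weaker inhibition. Compound 1 gives 7.3 nM in this assay. Compound 2 gives 94 nM in this assay, the higher of the two numbers; it stands apart from compound 1 by a gap that lies beyond the usual scatter of repeated measurements, so compound 2 is the weaker of the two measured binders.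

The step under consideration leads from compound 2 to compound 3 `N=C(N)NCCC[C@@H]1NC(=O)CNC(=O)C[C@@H](C(=O)O)NC(=O)[C@@H](c2ccccc2)NC(=O)[C@@H](CCCCN)NC1=O`, which has not yet been measured. The two compounds share every atom and bond; (the two compounds have the same atoms and bonds; at least one stereo element is drawn with a configuration in one of them and without one in the other: 1 of 5 stereo elements differ; a stereocentre at a saturated ring carbon is drawn S in compound 2 and R in compound 3). No step of this kind, a change at a single stereocentre with everything else kept, has been measured among the compounds shown, so there is no direct precedent for its size or direction. Among the compounds with values here, the gap between compound 1 and compound 2 shows only that changes within this ring can move the read-out by a large margin.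

Compound 3 is therefore expected to give about 40 nM in this assay, within a range of 8 nM to 300 nM; the expected step of a 2.4-fold lower number from compound 2 to compound 3 (0.37 log units; beyond the scatter) is uncertain in direction and is as likely to lie within the scatter as beyond it.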

Compound 3, half-maximal inhibitory concentration: 8.7 nM
For compound 3 the middle estimate is 4.6-fold (0.66 log units) above the measured one; measured number inside the range.
By their numbers in this assay, from the lowest: compounds 1 and 3 (each within the scatter of the next); then compound 2.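

Changing the configuration at one saturated ring carbon, the one that carries the 4-aminobutyl group, is enough to give an 11-fold lower number from compound 2 to compound 3 (1.03 log units; beyond the scatter) in this assay, with every atom and bond kept. This shows that the handedness at this position matters as much as any gap seen so far, and that the 4-aminobutyl group as such does not impose a high number, as the R form shows in a 1.2-fold higher number from compound 1 to compound 3 (0.08 log units; within the scatter), so that this chain and isopropyl cannot be told apart here. The one structural fact on record for the pair of compounds 2 and 3, which leaves the step without any measured explanation, is this: the fact that one of compounds 2 and 3 is drawn with a defined configuration and the other without, at the place where they differ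

The compounds shown leave open whether the same configuration dependence holds for isopropyl at this carbon, since no inverted partner of compound 1 stands beside it. They also leave open how far the position accepts other side chains in the R form, such as a longer chain ending in an amine, a chain ending in a carboxylic acid, or a benzyl group.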